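Hydroxyacetamide in place of aminochloropyridine on the shared core

The source may report more compounds than this note shows. Statements on the series, on what has been measured and on what is new or still open speak of the compounds shown alone.

Measured compounds:
- compound 1 `CCCC(=O)Nc1cc(Oc2ccc(Nc3nccc4[nH]cc(-c5ccc(F)cc5)c(=O)c34)cc2F)ccn1`: 64.6%
- compound 2 `CC(C)C(=O)Nc1cc(Oc2ccc(Nc3nccc4[nH]cc(-c5ccc(F)cc5)c(=O)c34)cc2F)ccn1`: 95.4%
- compound 3 `Nc1nccc(Oc2ccc(Nc3nccc4[nH]cc(-c5ccc(F)cc5)c(=O)c34)cc2F)c1Cl`: 85.7%

In a functional assay on MKN-45 cells (Homo sapiens) for antiproliferative activity, read by MTT assay, with a stated time of 72 h, tested at 10 uM (a higher number here means more inhibition at the concentration tested (going by the name of the read-out), a lower number less inhibition), compound 3 stands second highest of the three numbers. Its nearest neighbour is compound 2, the gap being a number 9.7 percentage points lower from compound 2 to compound 3 (within the scatter), which lies within the scatter. The step of a number 21.1 percentage points higher from compound 1 to compound 3 (beyond the scatter) is beyond the scatter, so compound 1 sits clearly lower than compound 3.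

Compound 4 is `O=C(CO)Nc1cc(Oc2ccc(Nc3nccc4[nH]cc(-c5ccc(F)cc5)c(=O)c34)cc2F)ccn1`. The change from compound 3 is 2-(((hydroxymethyl)carbonyl)amino)pyridin-4-yl in place of 2-amino-3-chloropyridin-4-yl on an oxygen on an aromatic ring. Among the compounds with values here, two measured steps bear on it, since both compound 1 and compound 2 carry an amide at this same position: a number 21.1 percentage points higher from compound 1 to compound 3 (beyond the scatter) and a number 9.7 percentage points lower from compound 2 to compound 3 (within the scatter). Within the amides themselves, a number 30.8 percentage points higher from compound 1 to compound 2 (beyond the scatter) shows that the acyl group alone can move the read-out considerably. The hydroxymethyl carbonyl amide of compound 4 is a third variant of that amide, so compound 4 is expected to fall between compound 1 and compound 2, close to compound 3. The expected step is a number 5.7 percentage points lower from compound 3 to compound 4 (within the scatter), not beyond the scatter. Compound 4 is therefore estimated at 80%, with a range from 58% to 97%.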

Compound 4, a percentage reported as inhibition, at one concentration (the size of the read-out at that concentration, not a potency): 63%
Beside the measured number, compound 4's estimate is 17 percentage points above it, within the range that was stated.
By their numbers in this assay, from the lowest: compounds 4 and 1 (each within the scatter of the next); then compounds 3 and 2 (each within the scatter of the next).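

In this assay, hydroxymethyl in place of isopropyl on the carbonyl carbon gives a large step, a number 32.4 percentage points lower from compound 2 to compound 4 (beyond the scatter), whereas hydroxy in place of ethyl on the saturated chain carbon gives a number 1.6 percentage points lower from compound 1 to compound 4 (within the scatter), so these two amides cannot be told apart. Among the amides at this position, the read-out therefore depends on the acyl group, and only the isopropyl amide stays within the scatter of the 2-amino-3-chloropyridin-4-yl compound, while the hydroxymethyl amide gives a number 22.7 percentage points lower from compound 3 to compound 4 (beyond the scatter). No measurement shown offers a reason for these steps.

On these data alone, the change from the 2-amino-3-chloropyridin-4-yl group removes the chlorine and adds the amide together, so their separate shares remain unknown. Also open, as far as these compounds go, is how a cyclopropyl, a tert-butyl or a methoxymethyl group on the carbonyl carbon would read.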